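A few compounds are considered here, and "the series" means these few. Any claim that something is new, unique, unknown or untested is made for them only; others in the source may bear on it.

In a functional assay on HeLa cells (Homo sapiens) for inhibition, read by CCK-8 assay, with a stated time of 48 h (a higher number here means a weaker inhibitor, a lower number a stronger inhibitor), compound 1 `COc1cc(-c2ccnc3cc(-c4ccc(C)cc4)nn23)cc(OC)c1OC` gives 21 nM, compound 2 `COc1cc(-c2ccnc3cc(-c4ccc(C)c(C)c4)nn23)cc(OC)c1OC` gives 241 nM and compound 3 `COc1cc(-c2ccnc3cc(-c4ccccc4)nn23)cc(OC)c1OC` gives 458 nM. Compound 3 thus stands level with compound 2, with a 1.9-fold higher number from compound 2 to compound 3 (0.28 log units; within the scatter), but far from compound 1, with a 22-fold higher number from compound 1 to compound 3 (1.34 log units; beyond the scatter). Compound 4 `COc1cc(-c2ccnc3cc(-c4ccc5cc[nH]c5c4)nn23)cc(OC)c1OC` has 1H-indol-6-yl in place of phenyl on an aromatic carbon of the shared core: 1H-indol-6-yl in place of phenyl on an aromatic carbon. Within the data shown here, no measured compound carries this group, so the steps offer only indirect guidance. Still, an 11-fold higher number from compound 1 to compound 2 (1.06 log units; beyond the scatter) shows that small changes to this aryl group can move the number widely. A sizeable drop in the number is therefore expected, an estimated 6.5-fold lower number from compound 3 to compound 4 (0.82 log units; beyond the scatter). The estimate for compound 4 is 70 nM, with an expected range of 12 nM to 400 nM.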

Compound 4, half-maximal inhibitory concentration: 125 nM
Compound 4: middle estimate off by 1.8-fold (0.25 log units), on the low side, within the range that was stated.
By their numbers in this assay, from the lowest: compound 1; then compounds 4, 2 and 3 (each within the scatter of the next, the first and the last beyond it).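

In this assay, 1H-indol-6-yl in place of phenyl gives a 3.7-fold lower number from compound 3 to compound 4 (0.56 log units; beyond the scatter) and so shows that this position can take an aryl group with a second ring and a hydrogen-bond donor without losing activity. The group still does not match 4-methylphenyl, with a 6.0-fold higher number from compound 1 to compound 4 (0.77 log units; beyond the scatter), while it stands level with 3,4-dimethylphenyl, with a 1.9-fold lower number from compound 2 to compound 4 (0.29 log units; within the scatter). No measured evidence accounts for these differences. The compounds shown leave open whether the indole hydrogen on nitrogen matters, which a methyl group there would test, and how a methoxy or an amine on the phenyl ring would compare with methyl.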